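From 3-cyanophenyl to 4-(methoxycarbonyl)phenyl on a carbonyl carbon

The source may report more compounds than this note shows. Statements on the series, on what has been measured and on what is new or still open speak of the compounds shown alone.

Measured in a functional assay on MCF7 cells (Homo sapiens) for inhibition, read by MTT assay; on this read-out lower numbers stand for stronger inhibition of growth and higher numbers for weaker inhibition of growth:
Compound 1 `COc1cc2oc(-c3cccc(NC(=O)c4ccc(Br)cc4)c3)cc(=O)c2c(OC)c1OC`: 9650 nM
Compound 2 `COc1cc2oc(-c3cccc(NC(=O)c4cccc(C#N)c4)c3)cc(=O)c2c(OC)c1OC`: 41700 nM

Of these two, compound 2 stands highest at 41700 nM and is the weaker growth inhibitor in this assay. Compound 3 `COC(=O)c1ccc(C(=O)Nc2cccc(-c3cc(=O)c4c(OC)c(OC)c(OC)cc4o3)c2)cc1` has not yet been measured. It keeps the shared core and changes one group (4-(methoxycarbonyl)phenyl in place of 3-cyanophenyl on a carbonyl carbon), with 4-(methoxycarbonyl)phenyl in place of 3-cyanophenyl on a carbonyl carbon. Going by the values given here, one measured step bears on this change, at the same place (a 4.3-fold higher number from compound 1 to compound 2 (0.64 log units; beyond the scatter)). It is modest but beyond the scatter, so this place can move the number. Neither of its groups is the entering one, which leaves the size better supported than the direction. The entering group shares only the 4 in its name with the 4-bromophenyl of compound 1 at 9650 nM and this thin resemblance suggests a modest move toward lower numbers. The estimate amounts to a 2.1-fold lower number from compound 2 to compound 3 (0.32 log units; beyond the scatter) as the expected step. For compound 3 the estimated value is 20000 nM with an expected range from 7000 nM to 50000 nM in this assay once it is measured.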

Compound 3, concentration for 50% growth inhibition: 30300 nM
For compound 3 the middle estimate is 1.5-fold (0.18 log units) below the measured one; low and high end bracket the measured number.
By their numbers in this assay, from the lowest: compound 1; then compounds 3 and 2 (each within the scatter of the next).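

In this assay, the change from 3-cyanophenyl to 4-(methoxycarbonyl)phenyl on a carbonyl carbon gives a 1.4-fold lower number from compound 2 to compound 3 (0.14 log units; within the scatter), so this pair of groups cannot be told apart here, even though the step from compound 1 to compound 2 had shown that this place can move the number. The other comparison, with methoxycarbonyl in place of bromo on an aromatic carbon, gives a 3.1-fold higher number from compound 1 to compound 3 (0.50 log units; beyond the scatter), which shows that the 4-bromophenyl of compound 1 stands apart from both other groups and that a group carried at the 4 of the phenyl name does not by itself keep the number of compound 1. Nothing available explains why bromo and methoxycarbonyl differ in this way.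

As far as these compounds go, how far the lower number of compound 1 belongs to bromo itself remains open, and a 4-chlorophenyl or a 4-aminophenyl at this place would speak to that. A 4-cyanophenyl would also separate the effect of the nitrile from that of where it sits on the phenyl, and the carboxylic acid counterpart of compound 3 would show how the ester compares with its acid.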